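An Amino Group Enters the Core of Compound 2

This account rests on a few compounds, and the source may have more. Where it says the series, first, only, none or still open, it means among the compounds named here.

Measured so far in a functional assay on SK-MEL-2 cells (Homo sapiens) for cytotoxicity, read by sulforhodamine B assay, with a stated time of 48 h; a higher number here means a weaker inhibitor of growth, a lower number a stronger inhibitor of growth:
compound 1 `ClCc1ccccc1Cn1cnc2c(Cl)nc(Cl)nc21`: 2180 nM
compound 2 `ClCc1ccccc1Cn1cnc2c(Cl)ncnc21`: 2750 nM
compound 3 `ClCc1ccc(Cn2cnc3nc(Cl)nc(Cl)c32)cc1`: 1120 nM

Compound 2 gives the highest of these three numbers in this assay. Among the compounds with values here, its nearest neighbour is compound 1, and the only step among the three, a 1.3-fold higher number from compound 1 to compound 2 (0.10 log units; within the scatter), lies within the scatter, so no order can be claimed between compound 1 and compound 2. Within the data shown here, compound 3 stands further away, lower by more than the scatter, so compound 3 inhibits growth more strongly than compound 2; no single-change step links these two, and only their values can be compared.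

Compound 4 `Nc1nc(Cl)c2ncn(Cc3ccccc3CCl)c2n1` differs from compound 2 by amino in place of hydrogen on an aromatic carbon. Among the measured compounds shown here, the one measured step, a 1.3-fold higher number from compound 1 to compound 2 (0.10 log units; within the scatter), removes a chloro from an aromatic carbon of the core and stays within the scatter; no measured step adds an amino group anywhere. There is therefore no basis for expecting a shift beyond the scatter in this assay in either direction, and the expected step is a 1.1-fold lower number from compound 2 to compound 4 (0.04 log units; within the scatter). Compound 4 is accordingly estimated at 2500 nM, with a range from 1000 nM to 6500 nM.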

Compound 4, concentration for 50% growth inhibition: 18600 nM
The estimate for compound 4 lay 7.4-fold (0.87 log units) below the measured number, and the stated range ends below it.
By their numbers in this assay, from the lowest: compounds 3, 1 and 2 (each within the scatter of the next, the first and the last beyond it); then compound 4.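

In this assay the aromatic carbon between two ring nitrogen atoms proves sensitive to the group it carries: amino in place of hydrogen gives a clear change (a 6.8-fold higher number from compound 2 to compound 4 (0.83 log units; beyond the scatter)), and amino in place of chloro on that same carbon gives a change of similar reach (an 8.5-fold higher number from compound 1 to compound 4 (0.93 log units; beyond the scatter)). Hydrogen and chloro at this carbon had stayed within the scatter of each other (a 1.3-fold higher number from compound 1 to compound 2 (0.10 log units; within the scatter)), so the earlier compounds gave no sign that this position mattered; of the three groups shown here, only amino moves the number beyond the scatter, towards weaker inhibition of growth. No measurement offered here explains why the amino group has this effect.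

The compounds shown leave open whether a methylamino or dimethylamino group, or a methoxy group, on this carbon would give a number close to that of compound 4 or one close to those of compound 1 and compound 2. They also leave open whether amino in place of chloro would produce a step of like size on compound 3, which differs from compound 1 elsewhere in the molecule.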